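Dropping the methyl from the anilide of compound 2

The compounds below may be only part of what the source reports. "The series", "measured", "known", "first", "only" and "open" are said of these compounds alone.

In a functional assay on the whole organism for inhibition, with Rattus norvegicus as the target, read by paw edema, with stated times of 30 min and 5 h, at a dose of 0.28 mmol/kg by the oral route (on this read-out higher numbers stand for more inhibition at the one dose given (going by the name of the read-out) and lower numbers for less inhibition), compound 2 `COc1ccc(-n2nc(C(=O)Nc3ccc(C)cc3)nc2-c2cc(OC)c(OC)c(OC)c2)cc1` gives 42%, the lowest of the three numbers measured. Compound 1 `CNC(=O)c1nc(-c2cc(OC)c(OC)c(OC)c2)n(-c2ccc(OC)cc2)n1` gives 50%, and compound 3 `COc1ccc(-n2nc(C(=O)Nc3ccc(C(=O)O)cc3)nc2-c2cc(OC)c(OC)c(OC)c2)cc1` gives 60%. The step of a number 8 percentage points lower from compound 1 to compound 2 (within the scatter) stays within the scatter, whereas a number 18 percentage points higher from compound 2 to compound 3 (beyond the scatter) lies beyond it. Compound 4 `COc1ccc(-n2nc(C(=O)Nc3ccccc3)nc2-c2cc(OC)c(OC)c(OC)c2)cc1` differs from compound 2 by a single change: hydrogen in place of methyl on an aromatic carbon. Within the data shown here, no measured step removes the methyl alone. The nearest comparisons are a number 18 percentage points higher from compound 2 to compound 3 (beyond the scatter), where the methyl became carboxy, and a number 8 percentage points lower from compound 1 to compound 2 (within the scatter), where the whole 4-methylphenyl entered; only the former moved beyond the scatter. Compound 4 is therefore expected to show a step of a number 6 percentage points higher from compound 2 to compound 4 (within the scatter) that stays inside the scatter. Compound 4 is estimated at 48%, between 35% and 60%.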

Compound 4, a percentage reported as inhibition, in the whole organism at one dose (the size of the read-out at that dose, not a potency): 46%
Beside the measured number, compound 4's estimate is 2 percentage points above it, within the range that was stated.
By their numbers in this assay, from the lowest: compounds 2, 4, 1 and 3 (each within the scatter of the next, the first and the last beyond it).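

In this assay, the methyl on the aromatic carbon proves dispensable, with a number 4 percentage points higher from compound 2 to compound 4 (within the scatter). Carboxy at that same carbon is a different matter: a number 14 percentage points lower from compound 3 to compound 4 (beyond the scatter), so this position can register a change of group. Phenyl on the amide nitrogen also reads much like methyl there, with a number 4 percentage points lower from compound 1 to compound 4 (within the scatter).

Nothing available explains the carboxy result. On these data alone, whether an amine or a longer chain on this carbon would read like hydrogen or like carboxy remains open.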